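A few compounds are considered here, and "the series" means these few. Any claim that something is new, unique, unknown or untested is made for them only; others in the source may bear on it.

In a functional assay on B16-F10 cells (Mus musculus) for inhibition, with a stated time of 4 days (on this read-out higher numbers stand for weaker inhibition and lower numbers for stronger inhibition), compound 1 (`COc1cc(O)c(C(=O)/C=C/c2ccccc2C)c(OC)c1`) gives 3000 nM. Compound 2 (`COc1cc(O)c(C(=O)/C=C/c2ccccc2C(C)C)c(OC)c1`) gives 2700 nM, level with it within the scatter, while compound 3 (`COc1cc(O)c(C(=O)/C=C/c2ccc(O)cc2)c(OC)c1`) gives 6900 nM. Compound 1 therefore sits with compound 2, and only compound 3 stands clearly apart, with the highest number of the three.

Compound 4 (`COc1cc(O)c(C(=O)/C=C/c2c(C)cccc2C)c(OC)c1`) has not yet been measured. Its difference from compound 1 is methyl in place of hydrogen on an aromatic carbon, ortho to a large group and meta to a methyl group.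

Going by the values given here, no measured step places a group on this carbon, so the evidence is indirect. The nearest in kind is isopropyl in place of methyl, which gives a 1.1-fold lower number from compound 1 to compound 2 (0.05 log units; within the scatter). This supports expecting no step beyond the scatter in this assay. The other measured change, 4-hydroxyphenyl in place of 2-methylphenyl, gives a 2.3-fold higher number from compound 1 to compound 3 (0.36 log units; beyond the scatter). It replaces a whole group and says less about one added methyl, though its modest size helps set the width of the range.

The estimated step is a 1.1-fold lower number from compound 1 to compound 4 (0.03 log units; within the scatter). For compound 4 the estimated value is 2800 nM, with an expected range from 1300 nM to 6000 nM.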

Compound 4, half-maximal inhibitory concentration: 9900 nM
Estimate against measurement, compound 4: 3.5-fold (0.55 log units) below; the measured number lies above the stated range.
By their numbers in this assay, from the lowest: compounds 2 and 1 (each within the scatter of the next); then compounds 3 and 4 (each within the scatter of the next).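

Methyl in place of hydrogen on an aromatic carbon, ortho to a large group and meta to a methyl group, gives a 3.3-fold higher number from compound 1 to compound 4 (0.52 log units; beyond the scatter) in this assay and is the first measured change on this carbon, showing that the position is not indifferent to substitution and that the change here runs towards weaker inhibition. Enlarging the existing group, with isopropyl in place of methyl, gives only a 1.1-fold lower number from compound 1 to compound 2 (0.05 log units; within the scatter) and stays within the scatter, so a single added methyl on this carbon moves the number where that other alkyl change on the same ring does not. Nothing shown explains why this one methyl shifts the read-out, and no supporting measurement bears on it.

Compound 4 is the only compound shown with a group on this carbon, so it remains open whether fluorine, methoxy or an amine there would shift the number in the same direction, or whether any substituent at all would do so. Also open, going by these compounds, is whether the same methyl would give a similar step on a ring lacking the methyl group that compound 1 already carries.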